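Amide Swap on a Flavonol Core: From Bromophenyl to Dichloropyrimidinyl

This account rests on a few compounds, and the source may have more. Where it says the series, first, only, none or still open, it means among the compounds named here.

Compound 1 `O=C(Nc1cccc(-c2oc3cc(-c4ccc(F)cc4)ccc3c(=O)c2O)c1)c1ccc(F)cc1` is an amide built on a hydroxyflavone core. In a functional assay on A549 cells (Homo sapiens) for antiproliferative activity, read by CCK-8 assay, with a stated time of 72 h (on this read-out higher numbers stand for weaker inhibition and lower numbers for stronger inhibition), compound 1 gives 6930 nM. Compound 2 `O=C(Nc1cccc(-c2oc3cc(-c4ccc(F)cc4)ccc3c(=O)c2O)c1)c1ccc(Br)cc1` differs only by bromo in place of fluoro on an aromatic carbon and gives 13500 nM. The step of a 1.9-fold higher number from compound 1 to compound 2 (0.29 log units; within the scatter) shows that these two compounds cannot be told apart on this read-out; compound 2 stands beside compound 1 with no ranking possible between them.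

Compound 3 `O=C(Nc1cccc(-c2oc3cc(-c4ccc(F)cc4)ccc3c(=O)c2O)c1)c1cnc(Cl)nc1Cl` is not yet measured. It differs from compound 2 as follows: 2,4-dichloropyrimidin-5-yl in place of 4-bromophenyl on a carbonyl carbon.

Among the measured compounds shown here, only one measured step bears on this change, and a 1.9-fold higher number from compound 1 to compound 2 (0.29 log units; within the scatter) was within the scatter. A heteroaromatic ring replacing the plain aromatic ring goes further than that step, yet there is nothing measured to suggest a direction. Compound 3 is therefore expected to give 10000 nM, with a range from 3000 nM to 35000 nM. That estimate means a step of a 1.4-fold lower number from compound 2 to compound 3 (0.13 log units; within the scatter) from compound 2 to compound 3, expected to stay within the scatter.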

Compound 3, half-maximal inhibitory concentration: > 100000 nM
Compound 3: no number, only a limit; the forecaster's own chance of this, stated with the estimate: 10%; middle value at least 10-fold (1.00 log units) from the limit.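

In this assay compound 3 has no number, only a limit of the assay: the limit of > 100000 nM in this assay, at which 1 of the 3 values shown sits.

Even so, this position clearly responds to the change of ring on the carbonyl carbon, which gives an at least 7.4-fold higher number from compound 2 to compound 3 (0.86 log units; beyond the scatter) and an at least 14-fold higher number from compound 1 to compound 3 (1.15 log units; beyond the scatter). Among the compounds shown here, exchanging one halogen for another on the phenyl ring had given only a 1.9-fold higher number from compound 1 to compound 2 (0.29 log units; within the scatter), so the earlier compounds showed no sensitivity here, whereas replacing 4-bromophenyl with 2,4-dichloropyrimidin-5-yl shows that the group on this carbonyl carbon can decide whether any activity is seen in this assay.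

This change brings in ring nitrogens and chlorines together, so the compounds shown cannot tell which of them accounts for the weaker inhibition. A pyrimidin-5-yl group without chlorine and a 2,4-dichlorophenyl group would pull these two parts apart.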